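A few compounds are considered here, and "the series" means these few. Any claim that something is new, unique, unknown or untested is made for them only; others in the source may bear on it.

Measured in a functional assay on A549 cells (Homo sapiens) for antiproliferative activity; on this read-out lower numbers stand for stronger inhibition of growth and higher numbers for weaker inhibition of growth:
- compound 1 `CC/C=C\[C@H](C)[C@H](OC(N)=O)[C@@H](C)[C@H](O)[C@@H](C)C/C(C)=C\[C@H](C)[C@@H](O)[C@@H](C)/C=C\[C@@H](O)C[C@H](O)[C@H](C)CO`: 3000 nM
- compound 2 `CC/C=C\[C@H](C)[C@H](OC(N)=O)[C@@H](C)[C@H](O)[C@@H](C)C/C(C)=C\[C@H](C)[C@@H](O)[C@@H](C)/C=C\[C@@H](O)C[C@@H]1OC(=O)[C@H](C)C[C@H]1C`: 11 nM

Not yet measured: compound 3 `CC/C=C\[C@H](C)[C@H](OC(N)=O)[C@@H](C)[C@H](O)[C@@H](C)C/C(C)=C\[C@H](C)[C@@H](O)[C@@H](C)/C=C\[C@@H](O)C[C@H]1CCC(=O)O1`.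

Compound 2 stands lowest of the two, at 11 nM. The change to compound 3 is a group of 6 heavy atoms (4 carbon, 2 oxygen; one five-membered non-aromatic ring with 1 hetero atom) in place of a group of 9 heavy atoms (7 carbon, 2 oxygen; one six-membered non-aromatic ring with 1 hetero atom), on a saturated chain carbon, two bonds along the chain from a double-bonded chain carbon and an oxygen on a saturated carbon. Within the data shown here, only one measured step bears on it: a 270-fold lower number from compound 1 to compound 2 (2.44 log units; beyond the scatter), a large step that brought in the six-membered ring group in place of an open group. Compound 3 keeps a ring, but a smaller one, so a rise in this assay is expected, smaller than that step. The expected step is a 14-fold higher number from compound 2 to compound 3 (1.13 log units; beyond the scatter). For compound 3 the estimate is 150 nM, with a range of 30 nM to 800 nM.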

Compound 3, concentration for 50% growth inhibition: 46 nM
For compound 3 the middle estimate is 3.3-fold (0.51 log units) above the measured one, within the range that was stated.
By their numbers in this assay, from the lowest: compound 2; then compound 3; then compound 1.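

In this assay the low numbers do not depend on a six-membered ring at this place: a 65-fold lower number from compound 1 to compound 3 (1.81 log units; beyond the scatter) comes with the five-membered ring group in place of the open group. The six-membered ring group still gives the lower number, with a 4.2-fold higher number from compound 2 to compound 3 (0.62 log units; beyond the scatter) as a modest step on moving to the five-membered ring group. Nothing at hand accounts for either step.

Ring size and the number of defined stereocentres change together from compound 2 to compound 3, and these compounds cannot separate the two. On these data alone, how a lactam ring or an open-chain ester would read at this place also remains open.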